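The source may report more compounds than this note shows. Statements on the series, on what has been measured and on what is new or still open speak of the compounds shown alone.

Measured compounds in the series:

compound 1 `O=C(O)c1cc(-n2c(-c3ccccc3)cc3c2CCCC3)ccc1O`: >= 60%
compound 2 `O=C(O)c1cc(-n2c(-c3ccccc3)cc3c2CCCC3)ccc1Cl`: 40%

In a functional assay on the whole organism (strain Wistar) for inhibition, with Rattus norvegicus as the target, read by paw edema, with stated times of 30 min and 3 h, at a dose of 200 mg/kg by the oral route (a lower number here means less inhibition, a higher number more inhibition at the dose given (going by the name of the read-out)), compound 1 gives >= 60%, which is a limit of the assay and not a number, as the entry the limit of >= 60% in this assay, at which 1 of the 2 values shown sits, records. For the measured compounds named here, compound 2 in this assay gives 40%, so the step of a number at least 20 percentage points lower from compound 1 to compound 2 (beyond the scatter) is the only measured step in the set, and it concerns the ring that carries the acid.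

Compound 3 `N#Cc1ccc(-c2cc3c(n2-c2ccc(O)c(C(=O)O)c2)CCCC3)cc1` differs from compound 1 in cyano in place of hydrogen on an aromatic carbon. Going by the values given here, the change sits on the phenyl, not on the acid-bearing ring, so the step from compound 1 to compound 2 does not bear on it directly; no measured step in the set covers a substituent on the phenyl. Compound 1 stands only at a limit, which further widens what can be said. Among the compounds with values here, with no relevant step to lean on, the expectation is a change within the scatter in this assay, that is a number no higher from compound 1 to compound 3 (the limit leaves the size open), and a fair chance that a limit is reported again. Compound 3 is therefore estimated at 60%, within 45% to 75%.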

Compound 3, a percentage reported as inhibition, in the whole organism at one dose (the size of the read-out at that dose, not a potency): 0%
For compound 3 the middle estimate is 60 percentage points above the measured one, and the stated range ends above it.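

The change from phenyl to 4-cyanophenyl, on an aromatic carbon para to a large group, gives a number at least 60 percentage points lower from compound 1 to compound 3 (beyond the scatter) in this assay. Until now the only measured step lay on the ring that carries the acid; the phenyl is now shown to be a place where a single substitution matters, with compound 3 at 0% at the dose given. The value of compound 1, >= 60%, is a limit of the assay and not a number: the limit of >= 60% in this assay, at which 1 of the 3 values shown sits.

The compounds shown offer a single substituent on the phenyl, so they cannot say whether the loss belongs to the nitrile itself or to any group at this place, and a fluorine, a methoxy group or an amine in the same position would separate these readings. They also leave open how the cyano change behaves with the chloro of compound 2 in place of the hydroxy, and, since the read-out comes from one oral dose in the whole animal, they give no measured property that would account for the drop.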